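The source may report more compounds than this note shows. Statements on the series, on what has been measured and on what is new or still open speak of the compounds shown alone.

Working notes on the series. In a functional assay on HT-29 cells (Homo sapiens) for antiproliferative activity, read by MTT assay, with a stated time of 72 h (on this read-out higher numbers stand for weaker inhibition and lower numbers for stronger inhibition), compound 1 `CNc1nc(-c2cc(OC)c(OC)c(OC)c2)c(-c2ccc(OC)cc2)s1` gives 6.3 nM. Compound 2 `CCOc1ccc(-c2sc(NC)nc2-c2cc(OC)c(OC)c(OC)c2)cc1` carries methyl in place of hydrogen on a saturated chain carbon bound to an oxygen on an aromatic ring; in this assay compound 2 gives 3.2 nM, a step of a 2.0-fold lower number from compound 1 to compound 2 (0.29 log units; within the scatter). Compound 3 `COc1ccc(-c2sc(C)nc2-c2cc(OC)c(OC)c(OC)c2)cc1` has a different core, the difference being (methyl in place of methylamino on an aromatic carbon); in this assay compound 3 gives 1420 nM, a step of a 230-fold higher number from compound 1 to compound 3 (2.35 log units; beyond the scatter), the highest number of the three measured. Compound 4 `CCOc1ccc(-c2sc(C)nc2-c2cc(OC)c(OC)c(OC)c2)cc1` has not yet been measured and carries methyl in place of hydrogen on a saturated chain carbon bound to an oxygen on an aromatic ring, the same change, at the same place, as that between compound 1 and compound 2. This change is expected to give a step of about a 1.5-fold lower number from compound 3 to compound 4 (0.17 log units; within the scatter) because a 2.0-fold lower number from compound 1 to compound 2 (0.29 log units; within the scatter) lay within the scatter. Compound 4 is therefore expected to give roughly 950 nM in this assay, most likely between 350 nM and 2800 nM.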

Compound 4, half-maximal inhibitory concentration: 487 nM
Compound 4: the middle estimate sits 2.0-fold (0.29 log units) above what was measured; the range from low to high includes it.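

In this assay the change from methoxy to ethoxy gives a 2.9-fold lower number from compound 3 to compound 4 (0.46 log units; beyond the scatter) and matches the same change on the core of compound 1: the same change on two cores in this assay, a 2.0-fold lower number (0.29 log units; within the scatter) from compound 1 to compound 2 and a 2.9-fold lower number (0.46 log units; beyond the scatter) from compound 3 to compound 4, 1.5-fold (0.17 log units) apart, within the scatter of two such steps. Methyl in place of methylamino gives a 150-fold higher number from compound 2 to compound 4 (2.18 log units; beyond the scatter) with ethoxy present and matches the step seen with methoxy: the same change on two cores in this assay, a 230-fold higher number (2.35 log units; beyond the scatter) from compound 1 to compound 3 and a 150-fold higher number (2.18 log units; beyond the scatter) from compound 2 to compound 4, 1.5-fold (0.17 log units) apart, within the scatter of two such steps. Both changes therefore carry over between these cores with no gap beyond the scatter, but this rests on two pairs per change, and the ethoxy step lies within the scatter on one core and beyond it on the other, so it is not shown as a firm shift on both.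

As far as these compounds go, whether a longer chain such as propoxy would continue the ethoxy step remains open. So does the size of the step for an unsubstituted amine in place of methylamino.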